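Fluoro for methyl at two different places in the series

A few compounds are considered here, and "the series" means these few. Any claim that something is new, unique, unknown or untested is made for them only; others in the source may bear on it.

In a functional assay on PC-3 cells (Homo sapiens) for cytotoxicity, read by WST assay, with a stated time of 72 h (on this read-out lower numbers stand for stronger inhibition and higher numbers for weaker inhibition), compound 2 `Cc1ccc(C2(c3ccc(O)cc3)C(=O)Nc3c2ccc(F)c3F)cc1` gives 0.8 nM and compound 1 `O=C1Nc2c(ccc(F)c2F)C1(c1ccc(O)cc1)c1ccc(F)cc1` gives 8.6 nM. The two differ by fluoro in place of methyl on an aromatic carbon, and the step is an 11-fold higher number from compound 2 to compound 1 (1.03 log units; beyond the scatter). Compound 3 `Cc1ccc2c(c1C)NC(=O)C2(c1ccc(O)cc1)C1CCCCCC1` is reported only as a limit of the assay, > 1000 nM, which is the limit of > 1000 nM in this assay, at which 1 of the 3 values shown sits. How the core of compound 3 differs from the core of compound 2 is not broken down here. Compound 4 `Cc1c(F)ccc2c1NC(=O)C2(c1ccc(O)cc1)C1CCCCCC1` carries the same kind of change, (fluoro in place of methyl on an aromatic carbon), but at a different place: on an aromatic carbon of a six-membered aromatic ring of carbon only, part of a fused or bridged system of two rings, ortho to a methyl group, meta to a fused ring and para to a fused ring, rather than para to a large group. The expected step in this assay is a step that the limit leaves unreadable from compound 3 to compound 4, resting on the same kind of change having given an 11-fold higher number from compound 2 to compound 1 (1.03 log units; beyond the scatter). Compound 3 already sits at the limit > 1000 nM. Compound 4 is therefore estimated at 5000 nM, most probably reported again as a limit rather than a number.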

Compound 4, half-maximal inhibitory concentration: 30 nM
Beside the measured number, compound 4's estimate is 170-fold (2.22 log units) above it; measured number outside the range, below it.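

Fluoro in place of methyl on an aromatic carbon gives an at least 33-fold lower number from compound 3 to compound 4 (1.52 log units; beyond the scatter) in this assay, so the step seen on the core of compound 2 does not carry over to the core of compound 3 in direction or in size: the same change on two cores in this assay, an 11-fold higher number (1.03 log units; beyond the scatter) from compound 2 to compound 1 and an at least 33-fold lower number (1.52 log units; beyond the scatter) from compound 3 to compound 4, at least 350-fold (2.55 log units) apart, beyond the scatter of two such steps
Compound 3 stands at a limit of the assay (> 1000 nM).
The two pairs differ in both core and place of the change, which leaves unshown whether the core or the place sets the direction, and the numbers give no cause for the reversal.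

Open, going by these compounds, is whether the same change at the other methyl group of compound 3 follows either step. Also open, on these data alone, is how chloro, methoxy or an amine would compare with fluoro at the place changed in compound 4.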